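The compounds below may be only part of what the source reports. "The series", "measured", "known", "first", "only" and "open" are said of these compounds alone.

Measured so far in a functional assay on the whole organism with Rattus norvegicus as the target; a lower number here means that less compound is needed, a higher number that more compound is needed for the effect: compound 1 `COc1nc2nc(C(=O)c3ccccc3)cn2c(C)c1CC1CC1` gives 10 mg/kg; compound 2 `CCCCc1c(OC)nc2nc(C(=O)c3ccccc3)cn2c1CC` gives 10 mg/kg.

Compound 2 therefore stands level with compound 1 in this assay, the two values lying within the scatter of each other. Compound 3 `CCCCc1c(OC)nc2nc(C(=O)c3ccccc3)cn2c1C` is the next compound to be measured; it differs from compound 2 by hydrogen in place of methyl on a saturated chain carbon bound to an aromatic carbon. For the measured compounds named here, no pair of measured compounds shows this change, so the step can only be expected, and the expectation is for none beyond the scatter in this assay. Compound 3 is estimated at 10 mg/kg, with a range from 3 mg/kg to 30 mg/kg, which is expected to mean a step of no change at the digits printed from compound 2 to compound 3 (within the scatter).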

Compound 3, minimum effective dose: 2 mg/kg
Compound 3: the middle estimate sits 5.0-fold (0.70 log units) above what was measured; measured number below the stated range.
By their numbers in this assay, from the lowest: compound 3; then compounds 1 and 2 (each within the scatter of the next).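

In this assay, hydrogen in place of methyl on a saturated chain carbon bound to an aromatic carbon, which reads as ethyl to methyl, gives a 5.0-fold lower number from compound 2 to compound 3 (0.70 log units; beyond the scatter) and so shows that this place responds to a single carbon, something the level values of compound 1 and compound 2 could not show. Propyl in place of cyclopropyl gives a 5.0-fold lower number from compound 1 to compound 3 (0.70 log units; beyond the scatter) and so shows that the cyclopropyl compound also lies beyond the scatter of the best value here. Nothing measured accounts for either step. On these data alone, how a trifluoromethyl group or a hydroxymethyl group would read at the place of the methyl remains open.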